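Dimethylamino in place of diethylamino on compound 3

The compounds below may be only part of what the source reports. "The series", "measured", "known", "first", "only" and "open" are said of these compounds alone.

Measured in a functional assay on Caco-2 cells (Homo sapiens) for antiproliferative activity, with a stated time of 48 h; a lower number here means a stronger inhibitor, a higher number a weaker inhibitor:
Compound 1 `CCN(CC)c1ccc(-c2ccc(C(C)=O)cc2)nn1`: 15000 nM
Compound 2 `CCN(CC)c1ccc(-c2ccc(C(=O)O)cc2)nn1`: > 25000 nM, a limit of the assay
Compound 3 `CCOC(=O)c1ccc(-c2ccc(N(CC)CC)nn2)cc1`: 4000 nM

Among the two actual numbers, compound 3 gives the lower, 4000 nM. Compound 4 `CCOC(=O)c1ccc(-c2ccc(N(C)C)nn2)cc1` carries dimethylamino in place of diethylamino on an aromatic carbon. The measured steps all change the group on the carbonyl carbon: a 3.8-fold lower number from compound 1 to compound 3 (0.57 log units; beyond the scatter) and an at least 6.2-fold lower number from compound 2 to compound 3 (0.79 log units; beyond the scatter) lie beyond the scatter, while an at least 1.6-fold higher number from compound 1 to compound 2 (0.22 log units; that floor lies within the scatter) has a floor within it. None of them touches the amino group, so they give no size for this change. No step beyond the scatter is expected in this assay, and the estimated change is a 1.3-fold higher number from compound 3 to compound 4 (0.10 log units; within the scatter). For compound 4 the expected value is 5000 nM, with an estimated range from 1800 nM to 14000 nM.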

Compound 4, half-maximal inhibitory concentration: > 25000 nM
Compound 4 gave a limit, no number; the forecaster's own chance of this, stated with the estimate: 10%; middle value at least 5.0-fold (0.69 log units) away from the limit.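

Going by these compounds alone, the amino group, which none of the earlier steps touched, proves to matter in this assay: with the ethoxy on the carbonyl carbon kept, dimethylamino in place of diethylamino gives an at least 6.2-fold higher number from compound 3 to compound 4 (0.79 log units; beyond the scatter). The value for compound 4 is a limit of the assay, not a number, so this step sets only a floor for the change: the limit of > 25000 nM in this assay, at which 2 of the 4 values shown sit.

On these data alone, it remains open whether dipropylamino, a longer chain, would give a lower number than diethylamino. As far as these compounds go, it is also open whether a plain amino group or monoethylamino on that carbon would give a measurable number.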